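The source may report more compounds than this note shows. Statements on the series, on what has been measured and on what is new or still open speak of the compounds shown alone.

Measured compounds:
compound 1 `NS(=O)(=O)c1ccc(Nc2nc(N/N=C/c3ccc(C(F)(F)F)cc3)nc(Nc3ccccc3)n2)cc1` gives 3070 nM in a functional assay on SR cells (Homo sapiens) for inhibition, read by sulforhodamine B assay, with a stated time of 48 h; a higher number here means a weaker inhibitor of growth, a lower number a stronger inhibitor of growth
compound 2 `Cc1nn(-c2ccccc2)cc1/C=N/Nc1nc(Nc2ccccc2)nc(Nc2ccc(S(N)(=O)=O)cc2)n1` gives 2450 nM in this assay

Going by the values given here, compound 2 holds the lower of the two numbers, but its only neighbour is compound 1, and the single measured step, a 1.3-fold lower number from compound 1 to compound 2 (0.10 log units; within the scatter), is within the scatter; so the two compounds cannot be told apart on these data.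

Compound 3 `NS(=O)(=O)c1ccc(Nc2nc(N/N=C/c3ccccn3)nc(Nc3ccccc3)n2)cc1` has not yet been measured. It differs from compound 2 in one place: pyridin-2-yl in place of 3-methyl-1-phenyl-1H-pyrazol-4-yl on a carbon with a double bond to nitrogen. Among the compounds with values here, the only step that bears on this change is the one from compound 1 to compound 2, where the group on the same carbon with a double bond to nitrogen was exchanged and the number moved a 1.3-fold lower number from compound 1 to compound 2 (0.10 log units; within the scatter). That exchange, also between two aromatic groups of different size and make-up, left the number essentially where it was. On that basis no step beyond the scatter is expected for compound 3, in either direction. The step from compound 2 to compound 3 is estimated as a 1.1-fold higher number from compound 2 to compound 3 (0.03 log units; within the scatter). Compound 3 is therefore expected to give about 2600 nM in this assay, with a range from 900 nM to 8000 nM.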

Compound 3, concentration for 50% growth inhibition: 330 nM
Beside the measured number, compound 3's estimate is 7.9-fold (0.90 log units) above it, outside the stated range (below it).
By their numbers in this assay, from the lowest: compound 3; then compounds 2 and 1 (each within the scatter of the next).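

Going by these compounds alone, the group on the carbon with a double bond to nitrogen is not indifferent in this assay, as the single earlier step had suggested: pyridin-2-yl in place of 3-methyl-1-phenyl-1H-pyrazol-4-yl gives a clear change (a 7.4-fold lower number from compound 2 to compound 3 (0.87 log units; beyond the scatter)), and pyridin-2-yl in place of 4-(trifluoromethyl)phenyl gives one of like size (a 9.3-fold lower number from compound 1 to compound 3 (0.97 log units; beyond the scatter)). Compound 1 and compound 2 lie within the scatter of each other despite their different groups, and only compound 3 stands apart from them, so the lower number rests on this one entering group. Nothing given here accounts for the effect of pyridin-2-yl at this position.

From the compounds shown here alone, what remains open is whether the ring nitrogen of pyridin-2-yl matters or simply the smaller group, which unsubstituted phenyl, pyridin-3-yl or pyridin-4-yl at the same place could help to separate. Also open, going by these compounds, is whether a methyl group or an amine on the pyridine ring would keep the lower number.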